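Acetoxy to methoxy: a step with no direct guide

A few compounds are considered here, and "the series" means these few. Any claim that something is new, unique, unknown or untested is made for them only; others in the source may bear on it.

In a functional assay on SNO cells (Homo sapiens) for cytotoxicity, read by XTT assay, with a stated time of 24 h (on this read-out higher numbers stand for weaker inhibition and lower numbers for stronger inhibition), compound 1 (`CC(=O)Oc1cc(C)c(Cl)c2c1C(=O)C=CC2=O`) gives 28800 nM as its value, compound 3 (`CC(=O)Oc1c(C)cc(Cl)c2c1C(=O)C=CC2=O`) gives 28600 nM and compound 2 (`CC(=O)Oc1cc(OC(C)=O)c2c(OC(C)=O)c(C)cc(Cl)c2c1OC(C)=O`) gives 53500 nM on the same read-out. Compound 1 stands inside a tight group: its gaps to compound 3 and to compound 2 both lie within the scatter, so the three cannot be ranked.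

The next entry is compound 4 (`COc1cc(C)c(Cl)c2c1C(=O)C=CC2=O`). It keeps the core of compound 1 and carries a single change, methyl in place of acetyl on an oxygen on an aromatic ring. Within the data shown here, no measured pair isolates this change, so the data give no direct guide to its size or direction. Among the measured compounds shown here, the three values so far do not separate beyond the scatter, and compound 1 at 28800 nM serves as the anchor here. No step beyond the scatter is therefore expected, in either direction. The expected step is a 1.1-fold lower number from compound 1 to compound 4 (0.03 log units; within the scatter) and carries little weight on its own. The estimate in this assay for compound 4 is 27000 nM within an expected range from 11000 nM to 60000 nM on this read-out.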

Compound 4, half-maximal inhibitory concentration: 24600 nM
Compound 4: the middle estimate sits 1.1-fold (0.04 log units) above what was measured; the range from low to high includes it.
By their numbers in this assay, from the lowest: compounds 4, 3, 1 and 2 (each within the scatter of the next, the first and the last beyond it).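

Working from this assay, the acetoxy to methoxy exchange on an oxygen on an aromatic ring is the first one-place comparison in the series, and it reads as a 1.2-fold lower number from compound 1 to compound 4 (0.07 log units; within the scatter), so compound 1 and compound 4 cannot be told apart on this read-out. At this position, then, acetyl with its 3 heavy atoms, its double bond outside aromatic rings and its hydrogen-bond acceptor can give way to methyl with its 1 heavy atom, and the value stays within the scatter. No measurement to hand bears on why the two values stay together.

This is a single pair on one read-out, so it says nothing about whether a group further from methyl on the same oxygen, such as a free hydroxyl, a longer chain like n-butyl or a chain ending in an amine, would move the value beyond the scatter. From the compounds shown here alone, whether the same exchange from acetyl to methyl would also stay within the scatter on the core of compound 3 remains open as well.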